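Chalcone series: nitro to fluoro on the styryl ring

The compounds below may be only part of what the source reports. "The series", "measured", "known", "first", "only" and "open" are said of these compounds alone.

Working notes on three measured chalcones and one to be measured. Compound 1 `COc1cc(O)c(C(=O)/C=C/c2ccc(F)cc2)c(OC)c1`, compound 2 `COc1cc(OC)c(C(=O)/C=C/c2ccccc2SC)c(OC)c1` and compound 3 `COc1cc(OC)c(C(=O)/C=C/c2ccc([N+](=O)[O-])cc2)c(OC)c1` share the enone linking a trimethoxy- or dimethoxyhydroxy-substituted ring to a second benzene ring that carries one further substituent. In a functional assay on MCF7 cells (Homo sapiens) for cytotoxicity, with a stated time of 48 h (on this read-out higher numbers stand for weaker inhibition and lower numbers for stronger inhibition), compound 1 gives 8800 nM, compound 2 gives 9300 nM and compound 3 gives 5000 nM. Compound 3 has the smallest number of the three, yet its gaps to compound 1 and to compound 2 both lie within the scatter, so the three cannot be placed in any order on these numbers.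

Compound 4 `COc1cc(OC)c(C(=O)/C=C/c2ccc(F)cc2)c(OC)c1` has not yet been measured in this assay. It differs from compound 3 in one place: fluoro in place of nitro on an aromatic carbon. Going by the values given here, no measured pair shows this change on its own. Compound 1 carries the same fluoro group on the same ring, though with a hydroxy rather than a methoxy on the other ring, and its value of 8800 nM is the closest reference. The step from compound 3 to compound 4 is therefore expected to be small, toward a somewhat higher number, and likely within the scatter, with a 1.6-fold higher number from compound 3 to compound 4 (0.20 log units; within the scatter) as the estimated size. Compound 4 is expected to give about 8000 nM in this assay, with a range from 3000 nM to 20000 nM.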

Compound 4, half-maximal inhibitory concentration: 7700 nM
Beside the measured number, compound 4's estimate is 1.0-fold (0.02 log units) above it, within the range that was stated.
By their numbers in this assay, from the lowest: compounds 3, 4, 1 and 2 (each within the scatter of the next).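

In this assay the change of fluoro in place of nitro on an aromatic carbon, para to a large group, can now be read on its own (a 1.5-fold higher number from compound 3 to compound 4 (0.19 log units; within the scatter)), and the step lies within the scatter, so on these numbers the two groups cannot be told apart at this position. Compound 4 also links the other two compounds to the series, giving a 1.1-fold lower number from compound 1 to compound 4 (0.06 log units; within the scatter) for methyl in place of hydrogen on an oxygen on an aromatic ring and a 1.2-fold lower number from compound 2 to compound 4 (0.08 log units; within the scatter) for 4-fluorophenyl in place of 2-(methylsulfanyl)phenyl on a double-bonded chain carbon bound to a double-bonded chain carbon, and both steps also lie within the scatter. Nothing at hand accounts for the size of any of these steps.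

As far as these compounds go, it remains open whether an amine or a carboxylic acid on the same aromatic carbon would give a step beyond the scatter. Also open, from the compounds shown here alone, is whether replacing a methoxy on the shared core with a longer chain, such as butoxy, would separate any compound from the rest of the series.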